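The compounds below may be only part of what the source reports. "The series", "measured", "known", "first", "only" and "open" are said of these compounds alone.

Measured in a functional assay on A549 cells (Homo sapiens) for antiproliferative activity, read by sulforhodamine B assay, with a stated time of 3 days; a lower number here means a stronger inhibitor of growth, a higher number a weaker inhibitor of growth:
Compound 1 `CN(C)c1ccc(C(=O)Nc2cccc(Nc3ncc(F)c(Nc4ccc(F)cc4)n3)c2)cc1`: > 10000 nM, a limit
Compound 2 `O=C(Nc1cccc(Nc2ncc(F)c(Nc3ccc(F)cc3)n2)c1)c1ccncc1`: 1650 nM
Compound 3 `O=C(Nc1cccc(Nc2ncc(F)c(Nc3ccc(F)cc3)n2)c1)c1ccccc1`: 37800 nM

Compound 3 holds the highest of the two actual numbers, the gap being a 23-fold higher number from compound 2 to compound 3 (1.36 log units; beyond the scatter). Compound 4 `O=C(NCCO)c1cccc(Nc2ncc(F)c(Nc3ccc(F)cc3)n2)c1` follows from (2-hydroxyethyl)carbamoyl in place of benzamido on an aromatic carbon, with (2-hydroxyethyl)carbamoyl in place of benzamido on an aromatic carbon. Within the data shown here, no measured step makes this exchange. The closest evidence comes from changing the group on the carbonyl carbon, which gave an at least 6.0-fold lower number from compound 1 to compound 2 (0.78 log units; beyond the scatter) and the large step already noted. Such changes clearly move the number in this assay, though their direction here cannot be read across. Since compound 3 already stands high, the expected change is modest and downward, an estimated 3.2-fold lower number from compound 3 to compound 4 (0.50 log units; beyond the scatter). For compound 4 the estimate is 12000 nM, with an expected range of 2500 nM to 50000 nM.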

Compound 4, concentration for 50% growth inhibition: 11900 nM
Compound 4: the middle estimate sits 1.0-fold (0.00 log units) above what was measured, within the range that was stated.
By their numbers in this assay, from the lowest: compound 2; then compound 4; then compound 3.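

The earlier compounds shown here changed only the group on the carbonyl carbon, whereas here the whole benzamido group gives way to a chain with no ring, and in this assay there is a 3.2-fold lower number from compound 3 to compound 4 (0.50 log units; beyond the scatter). A six-membered aromatic ring at this place is therefore not needed for a number lower than that of compound 3, yet the chain does not match the pyridin-4-yl amide, with a 7.2-fold higher number from compound 2 to compound 4 (0.86 log units; beyond the scatter). Nothing given here accounts for either step.

The compounds shown leave open whether the hydroxyl matters. They also leave open how an amine or a carboxylic acid in its place, or a longer chain, would read.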